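Replacing an Oxanylethyl Amine with a Hydroxydimethylcyclohexyl Amine

This account rests on a few compounds, and the source may have more. Where it says the series, first, only, none or still open, it means among the compounds named here.

Of the compounds shown here, three on a shared core have so far been tested in an assay on isolated protein for inhibition of protein kinase C delta type (Homo sapiens), read by TR-FRET, with a stated time of 2 h; a lower number here means a stronger inhibitor, a higher number a weaker inhibitor. Compound 1 `N#Cc1cnc(NCc2cnccc2C(F)(F)F)cc1N[C@H]1C[C@@H](O)C1` gives only a limit of the assay: in this assay compound 1 gives > 10000 nM. Compound 2 `N#Cc1cnc(NCc2cnccc2C(F)(F)F)cc1N[C@H]1C[C@H](O)C1` is its mirror image, and in this assay compound 2 also gives a limit, > 10000 nM. Compound 3 `N#Cc1cnc(NCc2cnccc2C(F)(F)F)cc1NCCC1CCOCC1` carries 2-(oxan-4-yl)ethyl on the nitrogen on the aromatic ring in place of 3-hydroxycyclobutyl; in this assay compound 3 likewise reaches only a limit, > 10000 nM. Compound 3 therefore stands on no number at all, and the same is true of the other two. The steps a step that the two limits leave unreadable from compound 1 to compound 2, a step that the two limits leave unreadable from compound 1 to compound 3 and a step that the two limits leave unreadable from compound 2 to compound 3 cannot be sized due to the limit of > 10000 nM in this assay, at which 3 of the 3 values shown sit, even though the fact that compounds 1 and 2 differ only in the configuration as drawn makes the first of them a pure configurational step.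

Compound 4 `CC1(C)C[C@H](Nc2cc(NCc3cnccc3C(F)(F)F)ncc2C#N)CC[C@H]1O` is not yet measured. It differs from compound 3 in one place: 4-hydroxy-3,3-dimethylcyclohexyl in place of 2-(oxan-4-yl)ethyl on a nitrogen on an aromatic ring. Within the data shown here, no measured step bears readably on this change, since all three values are limits. Compound 4 is therefore expected to give about 10000 nM, within a range of 2000 nM to 30000 nM. The step of a number no higher from compound 3 to compound 4 (the limit leaves the size open) is estimated with little confidence, and a further limit is the likeliest outcome.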

Compound 4, half-maximal inhibitory concentration: 2200 nM
For compound 4 the middle estimate is 4.5-fold (0.66 log units) above the measured one; low and high end bracket the measured number.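

In this assay, among these compounds, compound 4 gives 2200 nM, the only number among the four compounds that is not a limit, so a group on the nitrogen on the aromatic ring can give this core a readable number. With 4-hydroxy-3,3-dimethylcyclohexyl in place of 2-(oxan-4-yl)ethyl the change reads as an at least 4.5-fold lower number from compound 3 to compound 4 (0.65 log units; beyond the scatter), and with the same group in place of 3-hydroxycyclobutyl it reads as an at least 4.5-fold lower number from compound 2 to compound 4 (0.65 log units; beyond the scatter) and as an at least 4.5-fold lower number from compound 1 to compound 4 (0.65 log units; beyond the scatter). These sizes stay open on one side, and the steps among compound 1, compound 2 and compound 3 cannot be read, for one shared reason: the limit of > 10000 nM in this assay, at which 3 of the 4 values shown sit.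

From the compounds shown here alone, it remains open whether 4-hydroxycyclohexyl without the two methyl groups, plain cyclohexyl or 4-aminocyclohexyl on the same nitrogen would match the number of compound 4, so the gain cannot yet be assigned to any one part of the new group. Among the compounds shown here, also open is how the other configurations at the two defined stereocentres would compare with the one drawn in compound 4.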